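This account rests on a few compounds, and the source may have more. Where it says the series, first, only, none or still open, it means among the compounds named here.

Working notes on the series. In an ADME assay on BJ cells (Homo sapiens) for cytotoxicity, read by CellTiter-Glo and resazurin assay, with a stated time of 72 h (on this read-out lower numbers stand for an effect already at smaller amounts and higher numbers for an effect only at larger amounts of compound), compound 1 `CC(C)N(Cc1cccc(OCCCCCC(=O)O)c1)C(=O)c1ccc(-c2cccc3ccccc23)cc1` gives < 1.3 nM, which is a limit of the assay. Compound 2 `CC(C)N(Cc1cccc(OCCCCCC(=O)O)c1)C(=O)c1ccc(-c2cc3ccccc3n2S(=O)(=O)c2ccccc2)cc1` gives > 26000 nM in this assay, also a limit. Compound 3 `CCOC(=O)CCCCCOc1cccc(CN(C(=O)c2ccc(-c3cccc4ccccc34)cc2)C(C)C)c1` gives > 26000 nM in this assay, again a limit. Compound 3 therefore stands at the upper end of the values shown, with no number of its own, and compound 2 sits at that same end. Among the compounds with values here, the one measured step that reaches compound 3 is an at least 20000-fold higher number from compound 1 to compound 3 (4.30 log units; beyond the scatter); it runs between the two limits the limit of < 1.3 nM in this assay, at which 1 of the 3 values shown sits, and (the limit of > 26000 nM in this assay, at which 2 of the 3 values shown sit), so only its floor is known. Compound 4 `CCOC(=O)CCCCCOc1cccc(CN(C(=O)c2ccc(-c3ccc4[nH]ccc4c3)cc2)C(C)C)c1` differs from compound 3 by 1H-indol-5-yl in place of naphthalen-1-yl on an aromatic carbon. Within the data shown here, no measured step changes that aryl group while the ester is kept; compounds 1 and 2 only show that a change of the aryl group can carry a value from one limit to the other. Compound 4 is expected to remain near the upper limit, giving a step that the limit leaves unreadable from compound 3 to compound 4. The estimate for compound 4 is 30000 nM, expected between 5000 nM and 150000 nM.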

Compound 4, half-maximal effective concentration: > 26000 nM
Compound 4 was reported as a limit (the forecaster's own chance of this, stated with the estimate: 80%); the middle value lies beyond the limit too.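

No step can be read from compound 3 to compound 4, since both are reported only as the same upper limit: the limit of > 26000 nM in this assay, at which 3 of the 4 values shown sit.

The compounds shown leave open whether 1H-indol-5-yl in place of naphthalen-1-yl changes the value at all, with the ester or with the acid of compound 1.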